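Swapping a difluorophenyl ring for a cyclooctyl ring

This account rests on a few compounds, and the source may have more. Where it says the series, first, only, none or still open, it means among the compounds named here.

Measured so far in a functional assay on PC-3 cells (Homo sapiens) for cytotoxicity, read by WST assay, with a stated time of 72 h; a lower number here means a stronger inhibitor, a higher number a weaker inhibitor

- Compound 1 `CCCOc1ccc(C2(c3ccc(O)cc3)C(=O)Nc3c2ccc(F)c3F)cc1` gives > 1000 nM (a limit of the assay)
- Compound 2 `O=C1Nc2c(ccc(F)c2F)C1(c1ccc(O)cc1)c1ccc(F)c(F)c1` gives 19 nM

Only two results are available here, and just one of them is an exact number. Compound 1 gives > 1000 nM in this assay, which is a limit and not a number. For the measured compounds named here, compound 2, at 19 nM, therefore holds the only exact value and serves as the starting point.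

Compound 3 `O=C1Nc2c(ccc(F)c2F)C1(c1ccc(O)cc1)C1CCCCCCC1` keeps the core of compound 2 and changes one group: cyclooctyl in place of 3,4-difluorophenyl on a saturated ring carbon. The incoming ring is non-aromatic and the outgoing one aromatic, although both groups have the same number of heavy atoms.

Going by the values given here, no measured step shows what such a swap does, so the expectation is uncertain and rests on compound 2 (19 nM) alone. A modest weakening is expected, and the estimated change is a 2.1-fold higher number from compound 2 to compound 3 (0.32 log units; beyond the scatter). For compound 3 the estimated value is 40 nM (expected range 6 nM to 300 nM) .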

Compound 3, half-maximal inhibitory concentration: > 1000 nM
Compound 3 gave a limit, no number (the forecaster's own chance of this, stated with the estimate: 8%); middle value at least 25-fold (1.39 log units) away from the limit.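

In this assay, putting cyclooctyl in place of 3,4-difluorophenyl on the saturated ring carbon gives an at least 52-fold higher number from compound 2 to compound 3 (1.72 log units; beyond the scatter). Until now, nothing showed how this position responds to a change of ring type, and this step shows that matching the heavy-atom count is not enough to keep the activity of compound 2: the two groups have the same number of heavy atoms, yet the outcome differs widely. Compound 3 gives a limit of the assay and not a number, so the step has a known minimum but no known full size: the limit of > 1000 nM in this assay, at which 2 of the 3 values shown sit.

The swap removes the aromatic ring and both fluorines in a single move, so the compounds shown cannot say which of these changes matters more. A plain phenyl ring would keep the aromatic ring without the fluorines, while a cyclohexyl or cyclopentyl ring would test whether a smaller non-aromatic ring of carbon only fares any better than cyclooctyl at this position.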